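The source may hold more compounds than are shown below. What is called first, only, known or untested is meant among the compounds shown, and "the series" means these compounds.

Three analogues built on one shared core have been measured in a physicochemical assay for solubility, measured as kinetic solubility; on this read-out higher numbers stand for higher solubility and lower numbers for lower solubility. Compound 1 `CNc1nccc(N2CC[C@H](NC(=O)Nc3ccc(CN(C)C)c(C(F)(F)F)c3)C2)n1` gives 102000 nM. Compound 2 `CNc1nccc(N2CC[C@H](NC(=O)Nc3ccc(C)c(Cl)c3)C2)n1` gives 72700 nM. Compound 3 `CNc1nccc(N2CC[C@H](NC(=O)Nc3ccc(OC(F)F)cc3)C2)n1` gives 92800 nM, a number that lies within the scatter of both compound 1 and compound 2, so the three cannot be told apart on this read-out. Compound 4 `CNc1nccc(N2CC[C@H](NC(=O)Nc3ccc(OC)cc3)C2)n1` has not yet been measured. It differs from compound 3 in one place: methyl in place of difluoromethyl on an oxygen on an aromatic ring. Within the data shown here, no step between measured compounds bears on this change, so the expectation rests on compound 3 alone. The expected change is a 1.0-fold higher number from compound 3 to compound 4 (0.01 log units; within the scatter), a step estimated to stay within the scatter, with no clear direction. Compound 4 is therefore expected to give 95000 nM, within a range from 55000 nM to 160000 nM.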

Compound 4, solubility: 92600 nM
The estimate for compound 4 lay 1.0-fold (0.01 log units) above the measured number, within the range that was stated.
By their numbers in this assay, from the lowest: compounds 2, 4, 3 and 1 (each within the scatter of the next).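

In this assay, among these compounds, methyl in place of difluoromethyl on an oxygen on an aromatic ring gives a 1.0-fold lower number from compound 3 to compound 4 (0.00 log units; within the scatter) and so stays within the scatter, the only step that can be read at this position. Replacing the whole aryl group, with 4-methoxyphenyl in place of 3-chloro-4-methylphenyl on an amide-type nitrogen, gives a 1.3-fold higher number from compound 2 to compound 4 (0.11 log units; within the scatter) and also stays within the scatter. Nothing available here accounts for either step. Still open, going by these compounds, is whether a longer chain such as ethyl on that oxygen would move the number beyond the scatter. The same question stands for a carboxylic acid carried on the aromatic ring.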